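A Hydroxy Group Added to a Fatty Acid Receptor Agonist

This account rests on a few compounds, and the source may have more. Where it says the series, first, only, none or still open, it means among the compounds named here.

Of the compounds shown here, two have so far been tested in a functional assay on HEK293 cells for agonist activity at Free fatty acid receptor 1 (Homo sapiens), read by fluorescence and calcium flux, with a stated time of 10 min; a lower number here means that less compound is needed, a higher number that more compound is needed for the effect. Compound 1, `COCCOc1ccc2c(c1)OC(COc1ccc(CCC(=O)O)c(F)c1)CC2`, gives 2370 nM in this assay. Compound 2, `CC#C[C@@H](CC(=O)O)c1ccc(OC[C@H]2COc3ccc(C)cc3O2)cc1`, gives 120 nM in this assay. Compound 2 therefore stands as the lower of the two numbers, and its gap to compound 1 lies beyond the usual scatter of repeated measurements. Compound 1 and compound 2 differ in several places at once. No single structural step can be read from their two values.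

Compound 3, `CC#C[C@@H](CC(=O)O)c1ccc(OC[C@H]2COc3ccc(CO)cc3O2)cc1`, has not yet been measured. It differs from compound 2 in one place: hydroxy in place of hydrogen on a saturated chain carbon bound to an aromatic carbon. Cut one bond further out, the same difference reads as methyl to hydroxymethyl. Among the measured compounds shown here, no measured pair in this set shows a change of this kind, so there is no direct precedent to lean on. A small change of this sort is expected to move the number only modestly, with the direction uncertain. The expected step is a 1.3-fold higher number from compound 2 to compound 3 (0.12 log units; within the scatter), close to the size of the scatter. Compound 3 is expected to give about 160 nM in this assay, within a range from 50 nM to 500 nM.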

Compound 3, half-maximal effective concentration: > 30000 nM
Compound 3: no number, only a limit; the forecaster's own chance of this, stated with the estimate: 5%; at least 180-fold (2.27 log units) between middle value and limit.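

In this assay, the change from methyl to hydroxymethyl proves far from minor, giving an at least 250-fold higher number from compound 2 to compound 3 (2.39 log units; beyond the scatter). Among the compounds shown here, this is the first step in the set that can be read at a single place, and it shows that the number at this saturated chain carbon bound to an aromatic carbon can respond very strongly to a change of only 1 heavy atom. For compound 3, > 30000 nM is a limit of the assay and not a number, so the step marks only the smallest size the change can have: the limit of > 30000 nM in this assay, at which 1 of the 3 values shown sits.

A single step cannot show whether this sharp rise belongs to the hydroxy group in particular or would follow other replacements of the methyl group, and a methoxymethyl, fluoromethyl or aminomethyl group at this place would help to separate those readings. It also leaves open how far the true value of compound 3 lies past the limit, and whether a longer chain such as ethyl at the same place would keep a number close to that of compound 2.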